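Swapping a Long Chain for a Bromophenyl Group

The source may report more compounds than this note shows. Statements on the series, on what has been measured and on what is new or still open speak of the compounds shown alone.

Among the compounds with values here, compound 3 `CCCCCCCCCCn1cc(/C=C/C(=O)c2ccc(NC(=O)CN3CCN(c4ccccc4F)CC3)cc2)nn1` gives 47800 nM in a functional assay on HeLa cells (Homo sapiens) for inhibition, read by MTT assay (on this read-out lower numbers stand for stronger inhibition and higher numbers for weaker inhibition), the highest of the three numbers measured so far. Within the data shown here, compound 1 `CCCCCCCCn1cc(/C=C/C(=O)c2ccc(NC(=O)CN3CCN(c4ccccc4F)CC3)cc2)nn1` gives 33800 nM, and the one single-place step available, a 1.4-fold higher number from compound 1 to compound 3 (0.15 log units; within the scatter), simply lengthens the chain. Compound 2 `CC(C)(C)OC(=O)N1CCN(CC(=O)Nc2ccc(C(=O)/C=C/c3cn(Cc4ccc(Br)cc4)nn3)cc2)CC1` gives 18900 nM; its value and that of compound 3 lie beyond the scatter of each other, yet compound 2 differs from compound 3 in two places, so no single step is shown. Compound 4 `O=C(CN1CCN(c2ccccc2F)CC1)Nc1ccc(C(=O)/C=C/c2cn(Cc3ccc(Br)cc3)nn2)cc1` arises from compound 3 by 4-bromophenyl in place of nonyl on a saturated chain carbon bound to an aromatic nitrogen. The chain step was within the scatter, so the value of compound 2, which carries the same 4-bromophenyl group, is the closest guide. Compound 4 is therefore expected to show a modest drop, a 2.2-fold lower number from compound 3 to compound 4 (0.34 log units; beyond the scatter). The estimate for compound 4 is 22000 nM, within 8000 nM to 60000 nM.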

Compound 4, half-maximal inhibitory concentration: 9120 nM
Compound 4: the middle estimate sits 2.4-fold (0.38 log units) above what was measured; measured number inside the range.
By their numbers in this assay, from the lowest: compound 4; then compounds 2, 1 and 3 (each within the scatter of the next, the first and the last beyond it).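

On a saturated chain carbon bound to an aromatic nitrogen, a ring-bearing 4-bromophenyl group gives clearly stronger inhibition than either straight chain in this assay, with a 5.2-fold lower number from compound 3 to compound 4 (0.72 log units; beyond the scatter) and a 3.7-fold lower number from compound 1 to compound 4 (0.57 log units; beyond the scatter), whereas lengthening the chain alone made no difference beyond the scatter. The far end of the molecule also counts: on an amine nitrogen in a ring, 2-fluorophenyl in place of tert-butoxycarbonyl gives a 2.1-fold lower number from compound 2 to compound 4 (0.32 log units; beyond the scatter). No available evidence explains either change. On these data alone, what a plain benzyl or a 4-chlorobenzyl group would give at this place stays open, and so does whether the ring or the bromine matters more.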